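The source may hold more compounds than are shown below. What is called first, only, known or untested is meant among the compounds shown, and "the series" means these compounds.

Compound 2 `N#Cc1ccc(-c2cnc3[nH]cc(-c4nnc(-c5ccc(Cl)cc5)o4)c(=O)c3c2)cc1` is tested in a functional assay on HCT-116 cells (Homo sapiens) for inhibition, read by MTT assay, with a stated time of 24 h, tested at 5 uM (a lower number here means less inhibition of growth, a higher number more inhibition of growth at the concentration tested), where compound 2 gives 17.9%. Compound 1 `O=c1c(-c2nnc(-c3ccc(F)cc3)o2)c[nH]c2ncc(-c3cccnc3)cc12` in this assay gives 11.1%, and the two numbers differ only within the usual scatter, so neither compound stands apart from the other. Compound 3 `O=c1c(-c2nnc(-c3ccc(Cl)cc3)o2)c[nH]c2ncc(-c3cccnc3)cc12` has not yet been measured; it differs from compound 2 by pyridin-3-yl in place of 4-cyanophenyl on an aromatic carbon. Within the data shown here, no step between measured compounds is known here, so the expected change in this assay from compound 2 to compound 3 is none beyond the scatter, estimated as a number 3.9 percentage points lower from compound 2 to compound 3 (within the scatter). Compound 3 is expected to give about 14%, within a range of 4% to 25%.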

Compound 3, percent growth inhibition at one concentration: 15.9%
Compound 3: the middle estimate sits 1.9 percentage points below what was measured; low and high end bracket the measured number.
By their numbers in this assay, from the lowest: compounds 1, 3 and 2 (each within the scatter of the next).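

In this assay pyridin-3-yl in place of 4-cyanophenyl on this aromatic carbon gives a number 2 percentage points lower from compound 2 to compound 3 (within the scatter) with the chloro group kept, so these two aromatic rings are not told apart at this position. With pyridin-3-yl kept, chloro in place of fluoro gives a number 4.8 percentage points higher from compound 1 to compound 3 (within the scatter) and is likewise not told apart from it. Nothing measured on these compounds explains either step. As far as these compounds go, whether an amine or a carboxylic acid on this aromatic carbon would shift growth inhibition beyond the scatter remains open.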